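Trading a Methyl for Hydrogen on a Ring Oxygen

This account rests on a few compounds, and the source may have more. Where it says the series, first, only, none or still open, it means among the compounds named here.

Compound 1 `CCCCOc1cccc(C(=O)n2c(C)c(CC(=O)O)c3cc(OC)ccc32)c1`: 2500 nM
Compound 2 `CCCCOc1ccc(C(=O)n2c(C)c(CC(=O)O)c3cc(OC)ccc32)cc1`: 1600 nM
Compound 3 `CCCCOc1ccc(C(=O)n2c(C)c(CCCCC(=O)O)c3cc(OC)ccc32)cc1`: 4500 nM

In an assay on isolated protein for inhibition of prostaglandin D2 receptor (Mus musculus) (on this read-out higher numbers stand for weaker inhibition and lower numbers for stronger inhibition), compound 2 gives the lowest of the three numbers. Compound 1 lies within the usual scatter of compound 2, so the two cannot be told apart. Compound 3 does differ: a 2.8-fold higher number from compound 2 to compound 3 (0.45 log units; beyond the scatter), and that step comes from lengthening the acid-bearing chain on the shared core.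

Compound 4 `CCCCOc1ccc(C(=O)n2c(C)c(CC(=O)O)c3cc(O)ccc32)cc1` has not been measured. It differs from compound 2 in one place: hydrogen in place of methyl on an oxygen on an aromatic ring, that is, methoxy becomes hydroxy on the ring of the shared core.

Within the data shown here, none of the measured steps touches this oxygen; the only step known, from compound 2 to compound 3, changes the acid chain and so says nothing about the ring oxygen. Without a bearing step, the expectation for compound 4 in this assay is a number close to that of compound 2, with no step beyond the scatter, but with a wide range to reflect the lack of evidence: a 1.3-fold higher number from compound 2 to compound 4 (0.10 log units; within the scatter) is expected. The estimate for compound 4 is 2000 nM, between 600 nM and 6500 nM.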

Compound 4, half-maximal inhibitory concentration: > 10000 nM
Compound 4 gave a limit, no number; the forecaster's own chance of this, stated with the estimate: 5%; at least 5.0-fold (0.69 log units) between middle value and limit.
By their numbers in this assay, from the lowest: compounds 2, 1 and 3 (each within the scatter of the next, the first and the last beyond it). At a limit, above all of these: compound 4.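

Among these compounds, the ring oxygen matters, which the earlier steps could not show because none of them touched it: changing methoxy to hydroxy removes only one methyl, yet gives an at least 6.2-fold higher number from compound 2 to compound 4 (0.79 log units; beyond the scatter). Compound 4 stands at a limit, not at a number: the limit of > 10000 nM in this assay, at which 1 of the 4 values shown sits.

For compound 2, then, losing this one methyl from an oxygen on an aromatic ring clearly weakens inhibition in this assay, a step beyond the scatter.

The compounds shown hold only methoxy and hydroxy on this oxygen, so it stays open whether the loss follows from the free hydroxy or from the missing methyl. An ethoxy group, or a fluorine in place of the oxygen, would show how much change this position allows.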